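The source may hold more compounds than are shown below. What is called first, only, known or untested is meant among the compounds shown, and "the series" means these compounds.

In an ADME assay (Rattus norvegicus) for activation, read by fluorescence, with a stated time of 60 min, tested at 10 ug/mL (a higher number here means that the compound crosses the layer faster, a lower number that the compound crosses the layer more slowly), compound 1 `CCCCCCCCOC(=O)CN(C)C(=N)N` gives 2.42 10^-6 cm/s. Among the measured compounds shown here, this is the only number available, so it cannot yet be ranked as high or low against a related compound. Compound 2 `CCCCCCCCCCCCCCCCCCOC(=O)CN(C)C(=N)N` offers no comparison, as its entry reads "not determined" (no result reported).

The next compound to be tested is compound 3 `CCCCOC(=O)CN(C)C(=N)N`. Its structure departs from compound 1 by hydrogen in place of butyl on a saturated chain carbon, four bonds along the chain from an oxygen next to a carbonyl group. The rest of the molecule stays the same.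

For the measured compounds named here, no pair of measured compounds shows what such a change does in this assay, so any forecast here is tentative. Going by the values given here, the only anchor is compound 1 at 2.42 10^-6 cm/s. A small fall is expected, one that may not clear the usual scatter between repeated measurements. The expected change is a 1.6-fold lower number from compound 1 to compound 3 (0.21 log units; within the scatter). For compound 3 the estimated value is 1.5 10^-6 cm/s, with an expected range of 0.6 10^-6 cm/s to 3.5 10^-6 cm/s.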

Compound 3, apparent permeability: 1.81 10^-6 cm/s
Estimate against measurement, compound 3: 1.2-fold (0.08 log units) below; measured number inside the range.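

Hydrogen in place of butyl on a saturated chain carbon, four bonds along the chain from an oxygen next to a carbonyl group, gives a 1.3-fold lower number from compound 1 to compound 3 (0.13 log units; within the scatter) in this assay. Among the compounds shown here, this is the first pair in which this change can be read at this position, and it shows that a chain shorter by the four carbons of butyl leaves the read-out inside the spread expected from repeated measurements, so the octyl ester of compound 1 and the butyl ester of compound 3 cannot be told apart here. No measurement shown here accounts for how close the two results lie.

A single step within the scatter cannot show whether chain length matters at all in this series, and it gives no trend that could be carried to other chain lengths. Open questions are what a hexyl chain would give at the same place on the shared core, and whether a carboxylic acid in place of the ester would leave the read-out just as close to that of compound 1.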